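The compounds below may be only part of what the source reports. "The series", "measured", "known", "first", "only" and "open" are said of these compounds alone.

Measured so far in a functional assay on NCI-H520 cells (Homo sapiens) for inhibition, read by MTT assay, with a stated time of 48 h, tested at 10 uM; a higher number here means more inhibition at the concentration tested (going by the name of the read-out), a lower number less inhibition:

Compound 1 `COc1cc(Nc2cc(NC(=O)Nc3c(Cl)cccc3Cl)ncn2)cc(OC)c1`: 55.5%
Compound 2 `COc1cc(NC(=O)Nc2cc(Nc3ccc(OC)c(I)c3)ncn2)cc(OC)c1`: 46.5%
Compound 3 `COc1cc(NC(=O)Nc2cc(Nc3cc(C(F)(F)F)ccc3OC)ncn2)cc(OC)c1`: 63%

Among these three, compound 2 has the smallest number. The gap to compound 1 lies within the usual scatter of repeated measurements, so the two cannot be told apart; the gap to compound 3 lies beyond it, so compound 3 does show more inhibition than compound 2 in this assay.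

Compound 4 `COc1cc(NC(=O)Nc2cc(Nc3ccc(C)c(C)c3)ncn2)cc(OC)c1` shares the core of compound 2 and differs only in one place: 3,4-dimethylphenyl in place of 3-iodo-4-methoxyphenyl on a nitrogen on an aromatic ring. Among the compounds with values here, no step between two measured compounds that differ in a single place has been measured here, so no direct precedent for this exchange exists. The three measured compounds all vary in the same aryl group and their numbers spread over a modest range, which suggests that a further change of this group is expected to move the number only a little. The step from compound 2 to compound 4 is therefore estimated at a number 5.5 percentage points higher from compound 2 to compound 4 (within the scatter), a change not clearly beyond the scatter. Compound 4 is expected to give about 52% in this assay, with a likely range from 35% to 70%.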

Compound 4, a percentage reported as inhibition, at one concentration (the size of the read-out at that concentration, not a potency): 29.5%
For compound 4 the middle estimate is 22.5 percentage points above the measured one, outside the stated range (below it).
By their numbers in this assay, from the lowest: compound 4; then compounds 2, 1 and 3 (each within the scatter of the next, the first and the last beyond it).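

This is the first pair shown that differs in one place only, so the effect of the aryl group on the nitrogen can now be read by itself. In this assay, putting 3,4-dimethylphenyl in place of 3-iodo-4-methoxyphenyl gives a number 17 percentage points lower from compound 2 to compound 4 (beyond the scatter), so this position does respond to a change of group and the shared core alone does not set the number. Nothing measured here accounts for the size or direction of this step.

The exchange replaces both groups on the ring at once, so the compounds shown leave open whether the drop follows the loss of the iodine, the loss of the methoxy group, or both. Also open, as far as these compounds go, is how the number would respond to an amine or a carboxylic acid on this ring.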